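Phenyl replacing acetamidomethyl in an azetidine pyridyl ether series

This account rests on a few compounds, and the source may have more. Where it says the series, first, only, none or still open, it means among the compounds named here.

Of the compounds shown here, two sharing one core have been measured. Compound 1 `Clc1cncc(OC[C@@H]2CCN2)c1` carries a chloro group and in an assay on brain for binding affinity to Neuronal acetylcholine receptor; alpha4/beta2 (Rattus norvegicus), read by radioligand binding (on this read-out lower numbers stand for stronger inhibition and higher numbers for weaker inhibition), compound 1 gives 0.042 nM. Compound 2 `CC(=O)NCc1cncc(OC[C@@H]2CCN2)c1` carries acetamidomethyl in that place and in this assay compound 2 gives 0.54 nM; this is the higher of the two numbers, and the step of a 13-fold higher number from compound 1 to compound 2 (1.11 log units; beyond the scatter) lies beyond the scatter. Compound 3 `c1ccc(-c2cncc(OC[C@@H]3CCN3)c2)cc1` is the next variation: phenyl in place of acetamidomethyl on an aromatic carbon. Among the compounds with values here, only one measured step bears on this, the large one from compound 1 to compound 2, and it concerns a different entering group, so the size of the new step is uncertain. Since the entering phenyl, like chloro, brings no hydrogen-bond donors or acceptors, compound 3 is expected to give a number at or somewhat under that of compound 2, with the step of a 1.4-fold lower number from compound 2 to compound 3 (0.13 log units; within the scatter) estimated. Compound 3 is expected at 0.4 nM, within 0.07 nM to 3 nM.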

Compound 3, inhibition constant: 0.046 nM
For compound 3 the middle estimate is 8.7-fold (0.94 log units) above the measured one; the measured number lies below the stated range.
By their numbers in this assay, from the lowest: compounds 1 and 3 (each within the scatter of the next); then compound 2.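

Replacing acetamidomethyl with phenyl gives a 12-fold lower number from compound 2 to compound 3 (1.07 log units; beyond the scatter) in this assay and shows that this place on the shared core can carry a whole six-membered aromatic ring of carbon while the number stays low. Chloro and phenyl cannot be told apart here, since a 1.1-fold higher number from compound 1 to compound 3 (0.04 log units; within the scatter) is the step between them, even though one is a single atom and the other a full ring. The earlier loss, a 13-fold higher number from compound 1 to compound 2 (1.11 log units; beyond the scatter) in the same assay, therefore cannot be put down simply to a group larger than chloro entering this place, as phenyl is also larger.

Nothing available explains why acetamidomethyl stands apart from chloro and phenyl. As far as these compounds go, whether a phenyl ring bearing an amine or a carboxylic acid, or a longer chain without the amide, would keep the number low remains open.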